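Swapping the triazole substituent on a cytotoxic scaffold

The source may report more compounds than this note shows. Statements on the series, on what has been measured and on what is new or still open speak of the compounds shown alone.

For the measured compounds named here, compound 2 `C=C1C(=O)[C@]23C[C@@]1(O)CC[C@H]2c1ccc(O)c(C)c1[C@@H]3Cn1cc(-c2ccccn2)nn1` is the only member of this set with a numeric result: in a functional assay on SW480 cells (Homo sapiens) for cytotoxicity, read by MTT assay, with a stated time of 4 days (on this read-out lower numbers stand for stronger inhibition and higher numbers for weaker inhibition), compound 2 gives 410 nM. Compound 3 `Cc1c(O)ccc2c1[C@H](Cn1cc(-c3ccccn3)nn1)[C@@]13CC(=O)[C@@](C)(CC[C@@H]21)C3` reaches only a limit, as compound 3 gives > 20000 nM in this assay. Compound 1 `Cc1c(O)ccc2c1[C@H](Cn1cc(-c3ccc(F)cc3)nn1)[C@@]13CC(=O)[C@@](C)(CC[C@@H]21)C3` likewise stops at a limit, compound 1 giving > 20000 nM. The change from compound 3 to compound 1, (4-fluorophenyl in place of pyridin-2-yl on an aromatic carbon), therefore yields a step that the two limits leave unreadable from compound 3 to compound 1, because of the limit of > 20000 nM in this assay, at which 2 of the 3 values shown sit. The difference between the core of compound 2 and that of compound 3 is not broken down here. Compound 4 `C=C1C(=O)[C@]23C[C@@]1(O)CC[C@H]2c1ccc(O)c(C)c1[C@@H]3Cn1cc(-c2ccc(F)cc2)nn1` carries the same change on the core of compound 2: 4-fluorophenyl in place of pyridin-2-yl on an aromatic carbon. Going by the values given here, since the one measured instance of this change is unreadable, he expects a step of a 1.3-fold higher number from compound 2 to compound 4 (0.13 log units; within the scatter) from compound 2, resting on the value of compound 2 alone. He estimates compound 4 at 550 nM, within 150 nM to 2500 nM.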

Compound 4, half-maximal inhibitory concentration: 250 nM
Compound 4: middle estimate off by 2.2-fold (0.34 log units), on the high side; low and high end bracket the measured number.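

In this assay, 4-fluorophenyl in place of pyridin-2-yl gives a 1.6-fold lower number from compound 2 to compound 4 (0.21 log units; within the scatter), so on the core of compound 2 the two groups cannot be told apart on this read-out. On the other core the same change, from compound 3 to compound 1, cannot be read, because both compounds stop at a limit of the assay: the limit of > 20000 nM in this assay, at which 2 of the 4 values shown sit. This leaves one readable instance of the change, which does not show whether its size carries over from one core to the other.

The compounds shown leave open how an aminomethyl group or a carboxylic acid would fare on the five-membered aromatic ring with 3 nitrogen. They also leave open how a longer alkyl chain would fare there.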